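The source may hold more compounds than are shown below. What is called first, only, known or untested is meant among the compounds shown, and "the series" means these compounds.

Measured in a functional assay on PC-3 cells (Homo sapiens) for inhibition, read by MTT assay, with a stated time of 48 h, tested at 10 uM; a lower number here means less inhibition of growth, a higher number more inhibition of growth at the concentration tested:

- compound 1 `Cc1oc2c([C@H]3CCN(C)C[C@H]3O)c(O)cc(O)c2c(=O)c1C(O)c1ccc([N+](=O)[O-])cc1`: 24%
- compound 2 `Cc1oc2c([C@H]3CCN(C)C[C@H]3O)c(O)cc(O)c2c(=O)c1C(O)c1ccc(Cl)cc1`: 41%
- compound 3 `Cc1oc2c([C@H]3CCN(C)C[C@H]3O)c(O)cc(O)c2c(=O)c1C(O)c1cc(F)cc(F)c1`: 0%

Compound 3 stands lowest of the three, and compound 4 `Cc1oc2c([C@H]3CCN(C)C[C@H]3O)c(O)cc(O)c2c(=O)c1C(O)c1cccc(Cl)c1Cl` has yet to be measured. The change is 2,3-dichlorophenyl in place of 3,5-difluorophenyl on a saturated chain carbon bound to an aromatic carbon and an oxygen on a saturated carbon, with 2,3-dichlorophenyl in place of 3,5-difluorophenyl. Two measured steps leave the 3,5-difluorophenyl compound: the modest a number 24 percentage points lower from compound 1 to compound 3 (beyond the scatter) and the large a number 41 percentage points lower from compound 2 to compound 3 (beyond the scatter). Compound 2, the only measured chlorinated aryl, also exceeds compound 1, as a number 17 percentage points higher from compound 1 to compound 2 (beyond the scatter) shows. However, no measured compound carries the 2,3-dichlorophenyl group. A modest rise is therefore expected, and the expected step is a number 28 percentage points higher from compound 3 to compound 4 (beyond the scatter). Compound 4 is estimated at 28%, with an expected range of 6% to 52%.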

Compound 4, percent growth inhibition at one concentration: 20%
Compound 4: the middle estimate sits 8 percentage points above what was measured; measured number inside the range.
By their numbers in this assay, from the lowest: compound 3; then compounds 4 and 1 (each within the scatter of the next); then compound 2.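

Read in this assay, the 2,3-dichlorophenyl group stands above 3,5-difluorophenyl (a number 20 percentage points higher from compound 3 to compound 4 (beyond the scatter)) but short of 4-chlorophenyl (a number 21 percentage points lower from compound 2 to compound 4 (beyond the scatter)). Chlorine on the aryl ring therefore does not alone give the level of compound 2, and 2,3-dichlorophenyl cannot be separated from 4-nitrophenyl (a number 4 percentage points lower from compound 1 to compound 4 (within the scatter)). No evidence on hand accounts for these differences.

Still open, as far as these compounds go, is how an aryl ring carrying an amine, a carboxylic acid or a methoxy group would read at this place, and whether any such group would exceed compound 2.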